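A few compounds are considered here, and "the series" means these few. Any claim that something is new, unique, unknown or untested is made for them only; others in the source may bear on it.

Of the compounds shown here, two that share one core have been tested in a functional assay on NCI-H3122 cells (Homo sapiens) for inhibition, read by CellTiter-Glo, with a stated time of 72 h; a lower number here means a stronger inhibitor of growth, a higher number a weaker inhibitor of growth. Compound 1 `C=CC(=O)Nc1cc(Nc2ncc(Cl)c(Nc3ccccc3S(=O)(=O)C(C)C)n2)c(OC)cc1N1CCC(N2CCN(C)CC2)CC1` reads < 0.3 nM, which is a limit of the assay and not a number. Within the data shown here, compound 2 `C=CC(=O)Nc1cc(Nc2ncc(Cl)c(Nc3ccccc3S(=O)(=O)C(C)C)n2)c(OC)cc1N1CCN(C)CC1` gives 33 nM, the only actual number so far. Compound 3 `C=CC(=O)Nc1cc(Nc2ncc(Cl)c(Nc3ccccc3S(=O)(=O)C(C)C)n2)c(OC)cc1N1CCN(C(C)C)CC1` keeps all of compound 2 except one group: isopropyl in place of methyl on an amine nitrogen in a ring. Among the measured compounds shown here, no measured pair of compounds shows this change, so its effect has no direct guide. The expectation therefore rests on compound 2 at 33 nM, and no step beyond the usual scatter is expected. The expected step, a 1.3-fold lower number from compound 2 to compound 3 (0.12 log units; within the scatter), is small. For compound 3, the estimated value in this assay is 25 nM, with an expected range of 8 nM to 80 nM.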

Compound 3, concentration for 50% growth inhibition: < 0.3 nM
Compound 3 was reported as a limit; the forecaster's own chance of this, stated with the estimate: 3%; at least 83-fold (1.92 log units) between middle value and limit.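

Isopropyl in place of methyl on the amine nitrogen of the ring gives an at least 110-fold lower number from compound 2 to compound 3 (2.04 log units; beyond the scatter) in this assay, so a small change of group at this one nitrogen can move growth inhibition far beyond the scatter. Compound 3 reads < 0.3 nM, which is a limit of the assay and not a number. Only a smallest size for the step can be read, and its true size stays unknown, because of where the values stop: the limit of < 0.3 nM in this assay, at which 2 of the 3 values shown sit.

An ethyl group or a plain hydrogen on the same nitrogen would show whether the number falls gradually as the group changes or only with isopropyl. The compounds shown also leave open whether this change would have the same effect on a different core.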